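The compounds below may be only part of what the source reports. "The series", "measured", "known", "first", "only" and "open" are said of these compounds alone.

Of the compounds shown here, three from one series have been tested in a functional assay on HeLa cells (Homo sapiens) for inhibition, read by sulforhodamine B assay, with a stated time of 48 h; on this read-out lower numbers stand for stronger inhibition of growth and higher numbers for weaker inhibition of growth. Compound 1, with the structure `COC(=O)[C@@]1(C)CC[C@@H]2C3=C1CC[C@@H](C)[C@]3(C)C[C@@H]1c3cccc(C)c3N[C@H]21`, gives 22000 nM in this assay. Compound 2, `COC(=O)[C@@]1(C)CC[C@@H]2C3=C1CC[C@@H](C)[C@]3(C)C[C@@H]1c3cccc(Br)c3N[C@H]21`, differs from it by one change, (bromo in place of methyl on an aromatic carbon), and in this assay compound 2 gives 22000 nM; the step of no change at the digits printed from compound 1 to compound 2 (within the scatter) shows that this change left the number where it was. Compound 3, `COC(=O)[C@@]1(C)CC[C@@H]2C3=C1CC[C@@H](C)[C@]3(C)Cc1c2[nH]c2c(C)cccc12`, is built on a different core, and how its core differs from that of compound 1 is not broken down here; in this assay compound 3 gives 12000 nM, a number that lies within the scatter of both compound 1 and compound 2.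

Compound 4, `COC(=O)[C@@]1(C)CC[C@@H]2C3=C1CC[C@@H](C)[C@]3(C)Cc1c2[nH]c2c(Br)cccc12`, has not yet been measured in this assay. For the measured compounds named here, it is derived from compound 3 by bromo in place of methyl on an aromatic carbon, the same change, at the same kind of place, as the one that turned compound 1 into compound 2. The expected step of no change at the digits printed from compound 3 to compound 4 (within the scatter) rests on the earlier step of no change at the digits printed from compound 1 to compound 2 (within the scatter), which was flat. Compound 4 is therefore estimated to give 12000 nM in this assay, with an expected range from 6000 nM to 25000 nM.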

Compound 4, concentration for 50% growth inhibition: 18000 nM
For compound 4 the middle estimate is 1.5-fold (0.18 log units) below the measured one; measured number inside the range.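

In this assay, bromo in place of methyl on an aromatic carbon gives a 1.5-fold higher number from compound 3 to compound 4 (0.18 log units; within the scatter), and beside the earlier step the change reads the same on both cores: the same change on two cores in this assay, no change at the digits printed (within the scatter) from compound 1 to compound 2 and a 1.5-fold higher number (0.18 log units; within the scatter) from compound 3 to compound 4, 1.5-fold (0.18 log units) apart, within the scatter of two such steps. Within these four compounds, then, this change carries from the core of compound 1 to the core of compound 3 without any step or gap that can be told from the scatter. For the compounds shown here, this does not show that the two cores would respond alike to other changes, and it rests on only two pairs, both with flat steps, so it says nothing about a change that moves the number clearly.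

The compounds shown carry only methyl or bromo at this place, so it remains open whether an amine, a methoxy group or a carboxylic acid there would shift the number on either core, and whether it would shift it equally on both. Also open, as far as these compounds go, is what a carboxylic acid or an amide would do in place of the methyl ester that all four compounds share.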